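Chloro in Place of Hydrogen on Two Related Cores

The source may hold more compounds than are shown below. What is called first, only, known or untested is meant among the compounds shown, and "the series" means these compounds.

Compound 1, `CCC(C(=O)NCc1ccccc1)N1C(=O)CCC1=O`, gives 73.3 mg/kg in a functional assay on the whole organism (strain Albino Swiss CD1) with Mus musculus as the target, in the maximal electroshock model; on this read-out higher numbers stand for an effect only at larger amounts of compound and lower numbers for an effect already at smaller amounts.
Compound 2, `CCC(C(=O)NCc1ccccc1Cl)N1C(=O)CCC1=O`, gives 113 mg/kg in this assay.
Compound 3, `CC1CC(=O)N(C(C)C(=O)NCc2ccccc2)C1=O`, gives 106 mg/kg in this assay.

Compound 2 differs from compound 1 in one place: chloro in place of hydrogen on an aromatic carbon. This change gave a 1.5-fold higher number from compound 1 to compound 2 (0.19 log units; within the scatter), so the two values are indistinguishable within the usual scatter.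

Compound 3 is built on a core that is arranged differently from the core of compound 1; the difference between the two cores is not broken down here. In this assay compound 3 gives a number close to that of compound 2 and a little higher than that of compound 1, all of which lie within the scatter of one another.

Compound 4, `CC1CC(=O)N(C(C)C(=O)NCc2ccccc2Cl)C1=O`, is the unmeasured partner of compound 3 and differs from it as follows: chloro in place of hydrogen on an aromatic carbon. The place is described in exactly the same words as for the change from compound 1 to compound 2, so this is the same change on a different core.

From compound 3 to compound 4 the step expected is a 1.4-fold higher number from compound 3 to compound 4 (0.15 log units; within the scatter), because compound 1 to compound 2 showed a 1.5-fold higher number from compound 1 to compound 2 (0.19 log units; within the scatter) for the same change. That single example is the only basis, so the expectation is loose. The estimated value for compound 4 in this assay is 150 mg/kg, with a plausible range from 75 mg/kg to 300 mg/kg.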

Compound 4, dose for half-maximal effect: 85.9 mg/kg
Beside the measured number, compound 4's estimate is 1.7-fold (0.24 log units) above it; low and high end bracket the measured number.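

In this assay, chloro in place of hydrogen on an aromatic carbon of compound 3 gives a 1.2-fold lower number from compound 3 to compound 4 (0.09 log units; within the scatter), a step too small to be told apart from repeat-measurement noise. Set beside the step on the other core, this one shows no readable difference between the two cores: the same change on two cores in this assay, a 1.5-fold higher number (0.19 log units; within the scatter) from compound 1 to compound 2 and a 1.2-fold lower number (0.09 log units; within the scatter) from compound 3 to compound 4, 1.9-fold (0.28 log units) apart, within the scatter of two such steps. The result shows that the change made no readable difference to the number on either core, and that nothing here speaks against carrying it from one core to the other, but it does not show that the two cores truly respond alike, as two steps this small could hide a modest real effect and do not even settle its direction.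

The compounds shown leave open what a methoxy group, an amine or a carboxylic acid would do on the same aromatic carbon of either core, where a step large enough to read might or might not appear. They also leave open how chloro would behave on a third core, and two pairs of compounds are too few to support a general rule for this series.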